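Terminal group variation at the chain on the aromatic nitrogen

The compounds below may be only part of what the source reports. "The series", "measured", "known", "first", "only" and "open" are said of these compounds alone.

Measured compounds:
compound 1 `CN(C)CCCn1c(Cc2nn(C)c(=O)c3ccccc23)nnc1SCCCCCCCC(=O)Nc1ccc(Cl)cc1Cl` — 3700 nM
compound 2 `CN(C)CCCn1nc(Cc2nnc(SCCCCCCCC(=O)Nc3ccc(Cl)cc3Cl)n2C)c2ccccc2c1=O` — 2300 nM
compound 3 `Cn1c(Cc2nn(CCCO)c(=O)c3ccccc23)nnc1SCCCCCCCC(=O)Nc1ccc(Cl)cc1Cl` — > 30000 nM

In an assay on 32D cells for inhibition of interleukin-15 (Mus musculus), read by resazurin assay, with stated times of 30 min and 2.5 days, in the presence of a further agent that is not named here (on this read-out higher numbers stand for weaker inhibition and lower numbers for stronger inhibition), compound 1 gives 3700 nM and compound 2 gives 2300 nM. For compound 3 the result is > 30000 nM, which is a limit of this assay and not a number. Compound 3 therefore stands at the limit of > 30000 nM in this assay, at which 1 of the 3 values shown sits, with no number of its own, and the step of an at least 13-fold higher number from compound 2 to compound 3 (1.11 log units; beyond the scatter) is known only as a bound.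

Compound 4 `Cn1c(Cc2nn(CCC(=O)O)c(=O)c3ccccc23)nnc1SCCCCCCCC(=O)Nc1ccc(Cl)cc1Cl` differs from compound 3 by carboxy in place of hydroxymethyl on a saturated chain carbon, two bonds along the chain from an aromatic nitrogen. Going by the values given here, no measured step exchanges these two groups; the only measured step at this chain end is an at least 13-fold higher number from compound 2 to compound 3 (1.11 log units; beyond the scatter), which swaps a different pair of groups and says nothing about carboxy against hydroxymethyl. Starting from a limit, there is no basis for expecting a step in this assay beyond the scatter in either direction, and the most likely outcome for compound 4 is a limit once more. Compound 4 is accordingly expected near 30000 nM (range 10000 nM to 90000 nM), an expected step of a number no higher from compound 3 to compound 4 (the limit leaves the size open).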

Compound 4, half-maximal inhibitory concentration: > 30000 nM
Compound 4 ended at the assay's limit; the forecaster's own chance of this, stated with the estimate: 70%; the middle value sits exactly at the limit.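

In this assay, carboxy at the chain end, like hydroxy before it, gives no measurable value, and replacing the (dimethylamino)methyl of compound 2 is again a large change: an at least 13-fold higher number from compound 2 to compound 4 (1.11 log units; beyond the scatter). This step is known only as a bound, and among the chain variants compared here, only compound 2, with its dimethylamino end, gives a number. The step between compound 3 and compound 4 cannot be read, so the two end groups cannot be ordered: the limit of > 30000 nM in this assay, at which 2 of the 4 values shown sit.

Going by these compounds alone, whether the dimethylamino group is the only end group on this chain that keeps a measurable value remains open. A primary amine, a morpholine or a longer chain ending in dimethylamino would show how narrow that requirement is.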